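Methoxy for methylamino on a shared core

This account rests on a few compounds, and the source may have more. Where it says the series, first, only, none or still open, it means among the compounds named here.

Compound 1 `C=CCNc1nc(N)nc2c1ncn2[C@H]1C[C@H](N=[N+]=[N-])[C@@H](CO)O1` gives > 100000 nM as a limit
Compound 2 `CNc1nc(Cl)nc2c1ncn2[C@H]1C[C@H](N=[N+]=[N-])[C@@H](CO)O1` gives > 100000 nM as a limit

In an ADME assay on Vero cells (Chlorocebus sabaeus) for cytotoxicity, with a stated time of 5 days (on this read-out lower numbers stand for stronger inhibition and higher numbers for weaker inhibition), compound 2 stands at > 100000 nM as a limit of the assay and not a number. This is the limit of > 100000 nM in this assay, at which 2 of the 2 values shown sit, and no exact figure exists for either compound. Going by the values given here, compound 3 `COc1nc(Cl)nc2c1ncn2[C@H]1C[C@H](N=[N+]=[N-])[C@@H](CO)O1` carries methoxy in place of methylamino on an aromatic carbon and no measured step shows what such a swap does. The expectation rests on compound 2 with its limit of > 100000 nM alone. The expected change is a number no higher from compound 2 to compound 3 (the limit leaves the size open) in size, none beyond the scatter. Compound 3 is expected near 100000 nM within an estimated range from 40000 nM to 200000 nM and may well report a limit again.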

Compound 3, half-maximal inhibitory concentration: > 100000 nM
Compound 3: a limit, no number; the forecaster's own chance of this, stated with the estimate: 80%; the middle value sits exactly at the limit.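

Compound 2 and compound 3 both report a limit rather than a number, so no step can be read between them: the limit of > 100000 nM in this assay, at which 3 of the 3 values shown sit.

The compounds shown leave open whether methoxy in place of methylamino on an aromatic carbon changes the half-maximal inhibitory concentration at all.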